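This account rests on a few compounds, and the source may have more. Where it says the series, first, only, none or still open, it means among the compounds named here.

In a functional assay on HT-29 cells (Homo sapiens) for cytotoxicity, read by sulforhodamine B assay (a lower number here means a stronger inhibitor of growth, a higher number a weaker inhibitor of growth), compound 1 `CC1=CC[C@@H]([C@@](C)(O)CCCC(C)(C)NC(=S)N/N=C\c2ccccc2)CC1` gives 36500 nM, compound 2 `CC1=CC[C@@H]([C@@](C)(O)CCCC(C)(C)NC(=S)N/N=C\c2ccc(C)cc2)CC1` gives 80400 nM and compound 3 `CC1=CC[C@@H]([C@@](C)(O)CCCC(C)(C)NC(=S)N/N=C\c2cccc([N+](=O)[O-])c2)CC1` gives 57100 nM. Compound 3 stands within the scatter of both other compounds. The two steps that reach it are a 1.6-fold higher number from compound 1 to compound 3 (0.19 log units; within the scatter) and a 1.4-fold lower number from compound 2 to compound 3 (0.15 log units; within the scatter). Compound 4 `CC1=CC[C@@H]([C@@](C)(O)CCCC(C)(C)NC(=S)N/N=C\c2ccc([N+](=O)[O-])cc2)CC1` keeps the same atoms but joins them differently: 4-nitrophenyl in place of 3-nitrophenyl on a carbon with a double bond to nitrogen. Going by the values given here, no measured step makes this exact change, so the expectation rests on nearby steps on the same aromatic ring. Even the largest of these, a 2.2-fold higher number from compound 1 to compound 2 (0.34 log units; beyond the scatter), is only modest. The expected step is a 1.1-fold higher number from compound 3 to compound 4 (0.02 log units; within the scatter), with no clear direction and no change beyond the scatter. Compound 4 is estimated at 60000 nM, with an expected range of 30000 nM to 115000 nM.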

Compound 4, concentration for total growth inhibition: 62800 nM
For compound 4 the middle estimate is 1.0-fold (0.02 log units) below the measured one, within the range that was stated.
By their numbers in this assay, from the lowest: compounds 1, 3, 4 and 2 (each within the scatter of the next, the first and the last beyond it).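

In this assay, 4-nitrophenyl in place of 3-nitrophenyl gives a step within the scatter (a 1.1-fold higher number from compound 3 to compound 4 (0.04 log units; within the scatter)), so where the nitro sits on this ring makes no readable difference between these two compounds. Nitro in place of methyl (a 1.3-fold lower number from compound 2 to compound 4 (0.11 log units; within the scatter)) and nitro in place of hydrogen (a 1.7-fold higher number from compound 1 to compound 4 (0.24 log units; within the scatter)) also stay within the scatter. Nothing shown explains why these steps are so small. Still open, going by these compounds, is whether an amine or a carboxylic acid on the aromatic ring would give a step beyond the scatter.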